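From 3,4-dichlorophenyl to 3,4-dimethoxyphenyl on a shared core

A few compounds are considered here, and "the series" means these few. Any claim that something is new, unique, unknown or untested is made for them only; others in the source may bear on it.

Compound 1 `Nc1cc(N)c2nc(-c3ccccc3)c(Oc3ccc(Cl)c(Cl)c3)nc2c1`: 29500 nM
Compound 2 `CCOC(=O)[C@H](CCC(=O)O)NC(=O)c1ccc(CNc2nc3cc(N)cc(N)c3nc2-c2ccccc2)cc1`: < 100000 nM, a limit of the assay, not a number
Compound 3 `Nc1cc(N)c2nc(-c3ccccc3)c(NCc3ccc(Cl)c(Cl)c3)nc2c1`: 16200 nM

In a functional assay on DU-145 cells (Homo sapiens) for inhibition, read by sulforhodamine B assay, with a stated time of 48 h (on this read-out lower numbers stand for stronger inhibition of growth and higher numbers for weaker inhibition of growth), compound 3 gives 16200 nM, the lowest of the two numbers reported, but compound 1 sits within the scatter of it, so no order can be read between them. For compound 2 the assay reports only a limit (the limit of < 100000 nM in this assay, at which 1 of the 3 values shown sits). Compound 4 `COc1ccc(CNc2nc3cc(N)cc(N)c3nc2-c2ccccc2)cc1OC` differs from compound 3 by 3,4-dimethoxyphenyl in place of 3,4-dichlorophenyl on a saturated chain carbon bound to a nitrogen on an aromatic ring. For the measured compounds named here, no step between two measured compounds matches that change, so the expectation rests on the shared core alone: a step of a 1.5-fold higher number from compound 3 to compound 4 (0.19 log units; within the scatter), toward a weaker hold on growth, is expected, within the scatter of compound 3. Compound 4 is therefore estimated at 25000 nM, in the range 8000 nM to 80000 nM.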

Compound 4, concentration for 50% growth inhibition: 460 nM
Compound 4: middle estimate off by 54-fold (1.74 log units), on the high side; the whole stated range lies above it.
By their numbers in this assay, from the lowest: compound 4; then compounds 3 and 1 (each within the scatter of the next).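

In this assay, the change from 3,4-dichlorophenyl to 3,4-dimethoxyphenyl on a saturated chain carbon bound to a nitrogen on an aromatic ring gives a 35-fold lower number from compound 3 to compound 4 (1.55 log units; beyond the scatter), so growth inhibition at this position depends strongly on the group it carries. The earlier compounds shown here offered no step that could show this. Nothing among the data shown gives a cause for this step.

Going by these compounds, whether both methoxy groups are needed remains open. So does the effect of a hydroxyl group, an amine or a carboxylic acid on this phenyl ring.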